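The source may hold more compounds than are shown below. What is called first, only, known or untested is meant among the compounds shown, and "the series" means these compounds.

Three compounds have been measured so far in a functional assay on HepG2 cells (Homo sapiens) for inhibition, read by MTT assay, with a stated time of 120 h; on this read-out lower numbers stand for stronger inhibition and higher numbers for weaker inhibition:

compound 1 `CNC(=O)/C=C/c1ccc(NC(=O)Nc2ccc(Cl)c(C(F)(F)F)c2)cc1` gives 20400 nM
compound 2 `CC1CN(C(=O)/C=C/c2ccc(NC(=O)Nc3ccc(Cl)c(C(F)(F)F)c3)cc2)CC(C)O1` gives 45900 nM
compound 3 `CC(NC(=O)/C=C/Oc1ccc(NC(=O)Nc2cc(C(F)(F)F)ccc2Cl)cc1)c1ccccc1` gives 11900 nM

The value of compound 1 lies within the usual scatter of the value of compound 3, and compound 2 stands clearly apart from compound 1. Compound 4 `CNC(=O)C#Cc1ccc(NC(=O)Nc2ccc(Cl)c(C(F)(F)F)c2)cc1` has not yet been measured. It carries 2-(methylcarbamoyl)ethynyl in place of 2-(methylcarbamoyl)ethenyl on an aromatic carbon, para to a large group (2-(methylcarbamoyl)ethynyl in place of 2-(methylcarbamoyl)ethenyl on an aromatic carbon) and keeps the rest of compound 1 unchanged.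

Going by the values given here, only one measured step bears on this, and only loosely. That step, a 2.3-fold higher number from compound 1 to compound 2 (0.35 log units; beyond the scatter), is modest and replaces methylamino on a carbonyl carbon with 2,6-dimethylmorpholin-4-yl, so it does not touch the place that changes here. Among the compounds with values here, the data hold no measured step at that place. No shift beyond the scatter is therefore expected in this assay, and the expected change is a 1.0-fold lower number from compound 1 to compound 4 (0.01 log units; within the scatter) as an estimate. Compound 4 is estimated at 20000 nM, with an expected range of 8000 nM to 50000 nM as the likely span.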

Compound 4, half-maximal inhibitory concentration: 23300 nM
Compound 4: middle estimate off by 1.2-fold (0.07 log units), on the low side; measured number inside the range.
By their numbers in this assay, from the lowest: compounds 3, 1, 4 and 2 (each within the scatter of the next, the first and the last beyond it).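

Going by these compounds alone, the first measured step at this position, on an aromatic carbon para to a large group, reads a 1.1-fold higher number from compound 1 to compound 4 (0.06 log units; within the scatter) in this assay and lies within the scatter, so compound 1 and compound 4 cannot be told apart on this read-out. The 2-(methylcarbamoyl)ethynyl group thus serves here as well as 2-(methylcarbamoyl)ethenyl, with a triple bond in place of a double bond and the same count of heavy atoms, donors and acceptors. Nothing available accounts for this result or shows what lies behind it.

From the compounds shown here alone, it remains open whether this tolerance extends to a saturated 2-(methylcarbamoyl)ethyl chain or to a longer chain at this position. The compounds shown also leave open whether a carboxylic acid or a nitrile at the end of the ethynyl group would give a similar number in this assay.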